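This account rests on a few compounds, and the source may have more. Where it says the series, first, only, none or still open, it means among the compounds named here.

Measured compounds:
Compound 1 `CC(O)(CSc1ccc(F)cc1)c1nc(-c2ccc([N+](=O)[O-])c(C(F)(F)F)c2)no1` gives 8150 nM in a functional assay on LNCaP cells (Homo sapiens) for cytotoxicity, read by MTT assay; on this read-out lower numbers stand for stronger inhibition and higher numbers for weaker inhibition.
Compound 2 `CC(O)(CSc1ccc(Br)cc1)c1nc(-c2ccc([N+](=O)[O-])c(C(F)(F)F)c2)no1` gives 40000 nM in this assay.
Compound 3 `CC(O)(CSc1ccccc1)c1nc(-c2ccc([N+](=O)[O-])c(C(F)(F)F)c2)no1` gives 9670 nM in this assay.

Compound 3 has the second highest of these three numbers. Its nearest neighbour is compound 1: the step of a 1.2-fold higher number from compound 1 to compound 3 (0.07 log units; within the scatter) lies within the scatter, so the two cannot be told apart. Compound 2 stands furthest away; the step of a 4.1-fold lower number from compound 2 to compound 3 (0.62 log units; beyond the scatter) is modest but beyond the scatter.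

Compound 4 `CC(O)(CSc1ccc(Cl)cc1)c1nc(-c2ccc([N+](=O)[O-])c(C(F)(F)F)c2)no1` has not yet been tested. It differs from compound 3 in one place: chloro in place of hydrogen on an aromatic carbon. For the measured compounds named here, two measured steps bear on this, both of which swap the group at this same place on the phenylsulfanyl ring. Going from fluoro to hydrogen, a 1.2-fold higher number from compound 1 to compound 3 (0.07 log units; within the scatter), changed nothing beyond the scatter. Going from bromo to hydrogen, a 4.1-fold lower number from compound 2 to compound 3 (0.62 log units; beyond the scatter), gave a modestly lower number. Chloro has not been tried here, and the two known substituents at this position point in different directions, one to no change and one to a modestly higher number. The step of a 1.6-fold higher number from compound 3 to compound 4 (0.19 log units; within the scatter) is therefore expected to be small, leaning towards a higher number, with a wide range. For compound 4 the expected value in this assay is 15000 nM, between 6000 nM and 45000 nM.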

Compound 4, half-maximal inhibitory concentration: > 100000 nM
Compound 4: only a limit was reported; the forecaster's own chance of this, stated with the estimate: 5%; middle value at least 6.6-fold (0.82 log units) from the limit.
By their numbers in this assay, from the lowest: compounds 1 and 3 (each within the scatter of the next); then compound 2. At a limit, above all of these: compound 4.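

In this assay compound 4 gave no number, only a limit of the assay: the limit of > 100000 nM in this assay, at which 1 of the 4 values shown sits.

Even so, the steps to it are clear: putting chloro in place of hydrogen gives an at least 10-fold higher number from compound 3 to compound 4 (1.01 log units; beyond the scatter), putting chloro in place of fluoro gives an at least 12-fold higher number from compound 1 to compound 4 (1.08 log units; beyond the scatter), and putting chloro in place of bromo gives an at least 2.5-fold higher number from compound 2 to compound 4 (0.39 log units; beyond the scatter). The earlier compounds shown here suggested that a halogen at this place on the phenylsulfanyl ring changes the number by a modest step at most, yet here a single chlorine atom produces a large step, and chloro does not fall between fluoro and bromo on this read-out.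

The compounds shown leave open whether such a steep rise belongs to chloro alone or would also appear with other groups at this place, such as a methyl, a methoxy or an amine. As far as these compounds go, because compound 4 stands at a limit, how far it really lies from the other three also stays open, so the full size of the chloro step remains unknown.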